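This account rests on a few compounds, and the source may have more. Where it says the series, first, only, none or still open, it means among the compounds named here.

The measured compounds: compound 1 `CC1=CC[C@H](C(C)(C)NC(=S)NN)CC1` with 46700 nM; compound 2 `CC1=CC[C@H](C(C)(C)NC(=S)N/N=C/c2ccccc2)CC1` with 84400 nM; compound 3 `CC1=CC[C@H](C(C)(C)NC(=S)N/N=C/c2ccccc2O)CC1` with 17500 nM, all in a functional assay on MCF7 cells (Homo sapiens) for inhibition, read by sulforhodamine B assay, with a stated time of 48 h; a lower number here means a stronger inhibitor of growth, a higher number a weaker inhibitor of growth.

Compound 2 gives the highest of the three numbers; its value and that of compound 1 lie within the scatter of each other, while compound 3 sits clearly lower. Compound 4 `CC1=CC[C@H](C(C)(C)NC(=S)N/N=C/c2ccc(N(C)C)cc2)CC1` differs from compound 2 by dimethylamino in place of hydrogen on an aromatic carbon. For the measured compounds named here, the one step that bears on it is the aromatic substitution in the same ring: a 4.8-fold lower number from compound 2 to compound 3 (0.68 log units; beyond the scatter). A dimethylamino group is not a hydroxy group, so that step is only a loose guide; compound 2 and compound 3 are the whole basis. Compound 4 is therefore expected to show a modest lowering, a 2.4-fold lower number from compound 2 to compound 4 (0.38 log units; beyond the scatter), giving an estimate of 35000 nM with a range of 12000 nM to 100000 nM.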

Compound 4, concentration for total growth inhibition: > 100000 nM
Compound 4 was reported as a limit (the forecaster's own chance of this, stated with the estimate: 10%); middle value at least 2.8-fold (0.45 log units) from the limit.
By their numbers in this assay, from the lowest: compound 3; then compounds 1 and 2 (each within the scatter of the next). At a limit, above all of these: compound 4.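

In this assay compound 4 is reported only as a limit, not as a number: the limit of > 100000 nM in this assay, at which 1 of the 4 values shown sits. The step that can be read is a floor, an at least 1.1-fold higher number from compound 2 to compound 4 (0.07 log units; that floor lies within the scatter), so dimethylamino on this aromatic carbon, para to a large group, gives none of the lowering seen with hydroxy, a 4.8-fold lower number from compound 2 to compound 3 (0.68 log units; beyond the scatter). A substituent on this ring therefore does not lower the number as such, and compound 3 alone shows a lowering.

From the compounds shown here alone, how far compound 4 lies past its limit stays open. So does whether a methoxy group or a primary amine in this place would follow hydroxy or dimethylamino.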